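Trimming a methoxy group from a cytotoxic diaminoquinoxaline series

The compounds below may be only part of what the source reports. "The series", "measured", "known", "first", "only" and "open" are said of these compounds alone.

Compound 1 `CCOC(=O)[C@H](CCC(=O)O)NC(=O)c1ccc(Sc2nc3cc(N)cc(N)c3nc2-c2ccccc2)cc1`: limit < 100000 nM
Compound 2 `COc1cc(CNc2nc3cc(N)cc(N)c3nc2-c2ccccc2)cc(OC)c1OC`: limit < 50200 nM
Compound 3 `COc1ccc(CNc2nc3cc(N)cc(N)c3nc2-c2ccccc2)cc1OC`: limit < 100000 nM

Of the compounds shown here, three share one core and have been tested in a functional assay on IGROV-1 cells (Homo sapiens) for inhibition, read by sulforhodamine B assay, with a stated time of 48 h; a higher number here means that more compound is tolerated, a lower number that less compound is tolerated. None gave a number. In this assay compound 1 reached only the limit < 100000 nM. Compound 2 is known only as the limit < 50200 nM. Compound 3, too, stands at a limit, < 100000 nM. Going by the values given here, the single change between measured compounds, a step that the two limits leave unreadable from compound 2 to compound 3, cannot be read as a step because the limit of < 50200 nM in this assay, at which 1 of the 3 values shown sits, and the limit of < 100000 nM in this assay, at which 2 of the 3 values shown sit, are limits and not numbers, so nothing measured here tells how much a change of this kind shifts the read-out.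

Compound 4 `COc1ccc(CNc2nc3cc(N)cc(N)c3nc2-c2ccccc2)cc1` carries the difference (hydrogen in place of methoxy on an aromatic carbon), or, cut one bond further out, 3,4-dimethoxyphenyl to 4-methoxyphenyl. Among the compounds with values here, no measured step bears on it, and the nearest change of the same kind left no readable size. Within the data shown here, the expectation is therefore only that compound 4 behaves like its neighbours, with an estimated step that the limit leaves unreadable from compound 3 to compound 4 that is not believed to exceed the scatter. Compound 4 is expected to give about 30000 nM in this assay, within a wide range from 3000 nM to 100000 nM, and most likely again only as a limit.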

Compound 4, concentration lethal to 50% of the cells: 56200 nM
The estimate for compound 4 lay 1.9-fold (0.27 log units) below the measured number; the measured number falls inside the stated range.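

Compound 4 gives a real number, yet no step from compound 3 to compound 4 can be read, because compound 3 is known only as a limit: the limit of < 100000 nM in this assay, at which 2 of the 4 values shown sit.

The compounds shown leave open how far the read-out moves when hydrogen takes the place of methoxy on an aromatic carbon.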